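Replacing the pyrrolidin-1-yl of compound 1 with 4-fluorophenyl

The source may report more compounds than this note shows. Statements on the series, on what has been measured and on what is new or still open speak of the compounds shown alone.

Compound 1 `O=C(NCc1ccc(C(F)(F)F)nc1N1CCCC1)Nc1cccc2[nH]c(=O)ccc12` gives 0.94 nM in an assay on HEK cells for antagonist activity at transient receptor potential cation channel subfamily V member 1 (Homo sapiens), read by FLIPR (on this read-out higher numbers stand for weaker inhibition and lower numbers for stronger inhibition), the lowest of the three numbers measured. Compound 2 `CCCCCOc1nc(C(F)(F)F)ccc1CNC(=O)Nc1cccc2[nH]c(=O)ccc12` gives 2.72 nM, and compound 3 `O=C(NCc1ccc(C(F)(F)F)nc1SC1CCCCC1)Nc1cccc2[nH]c(=O)ccc12` gives 2.15 nM. Both exchanges at the same aromatic carbon weaken binding modestly: a 2.9-fold higher number from compound 1 to compound 2 (0.46 log units; beyond the scatter) and a 2.3-fold higher number from compound 1 to compound 3 (0.36 log units; beyond the scatter); between the two replacements there is only a 1.3-fold lower number from compound 2 to compound 3 (0.10 log units; within the scatter).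

Compound 4 `O=C(NCc1ccc(C(F)(F)F)nc1-c1ccc(F)cc1)Nc1cccc2[nH]c(=O)ccc12` differs from compound 1 by 4-fluorophenyl in place of pyrrolidin-1-yl on an aromatic carbon. Within the data shown here, no aromatic substituent at this carbon has yet been measured, so the two modest steps from compound 1 are the only guide. A step of similar size toward higher numbers is expected, a 2.7-fold higher number from compound 1 to compound 4 (0.42 log units; beyond the scatter), with compound 4 estimated at 2.5 nM, range 1 nM to 7 nM.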

Compound 4, half-maximal inhibitory concentration: 1.93 nM
The estimate for compound 4 lay 1.3-fold (0.11 log units) above the measured number; the range from low to high includes it.
By their numbers in this assay, from the lowest: compound 1; then compounds 4, 3 and 2 (each within the scatter of the next).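

An aromatic ring at this carbon behaves like the two non-aromatic replacements, with a 1.1-fold lower number from compound 3 to compound 4 (0.05 log units; within the scatter) and a 1.4-fold lower number from compound 2 to compound 4 (0.15 log units; within the scatter). 4-Fluorophenyl also leaves pyrrolidin-1-yl with the lowest number, giving a 2.1-fold higher number from compound 1 to compound 4 (0.31 log units; beyond the scatter). Nothing available explains this gap.

On these data alone, whether the gap belongs to pyrrolidin-1-yl alone or extends to other amines, such as piperidin-1-yl or dimethylamino, stays open. Phenyl without the fluorine would show whether that atom contributes to the number of compound 4.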